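Swapping an Aromatic Amine for a Chain

The source may hold more compounds than are shown below. What is called first, only, known or untested is meant among the compounds shown, and "the series" means these compounds.

The compounds here share one core and differ mainly in the group attached to a nitrogen on that core and in the amide side. Compound 1 `Nc1cccc(Nc2c(C(=O)NCc3ccc(F)cc3)nc(Br)c3cccnc23)c1` carries a 3-aminophenyl on that nitrogen. In a functional assay on HCT-116 cells (Homo sapiens) for cytotoxicity, read by MTT assay, with a stated time of 72 h (a lower number here means a stronger inhibitor, a higher number a weaker inhibitor), compound 1 gives > 10000 nM, which is a limit of the assay rather than a measured number, so its true potency is only bounded. This places compound 1 at the limit of > 10000 nM in this assay, at which 1 of the 3 values shown sits. Compound 2 `COc1cccc(CNC(=O)c2nc(Br)c3cccnc3c2N[C@H]2CC[C@H](N)CC2)c1` is a relative with a different amine and a different amide; in this assay compound 2 gives 6000 nM. Compound 3 `N[C@H]1CC[C@H](Nc2c(C(=O)NCc3ccccn3)nc(Br)c3cccnc23)CC1` belongs to the same set, but in this assay compound 3 is recorded as "not determined" (no result reported), so no result was reported for it.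

Compound 4 `CNCCCNc1c(C(=O)NCc2ccc(F)cc2)nc(Br)c2cccnc12` is the one still to be measured. It differs from compound 1 in a single place: 3-(methylamino)propyl in place of 3-aminophenyl on a nitrogen on an aromatic ring. Going by the values given here, no step between two measured compounds covers a change of this kind, so the expectation rests on compound 1 and on the general level of the set. The starting point is a limit, which leaves the direction uncertain; the expected step of an at least 1.2-fold lower number from compound 1 to compound 4 (0.09 log units; that floor lies within the scatter) is modest, not clearly beyond the scatter. Compound 4 is expected to give about 8000 nM in this assay, with a range from 2000 nM to 30000 nM, and a fair chance remains that only a limit is reported again.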

Compound 4, half-maximal inhibitory concentration: 9000 nM
Estimate against measurement, compound 4: 1.1-fold (0.05 log units) below; the range from low to high includes it.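

The value of compound 1, > 10000 nM, is a limit of the assay. In this assay compound 4 has a measured value, so an open chain on this nitrogen gives a number that can be used as a reference point, while the comparison with the aromatic group remains incomplete: the step reads as an at least 1.1-fold lower number from compound 1 to compound 4 (0.04 log units; that floor lies within the scatter), and only this floor is known, not the true size of the change. Replacing 3-aminophenyl with 3-(methylamino)propyl therefore shows that this position tolerates a ring-free group without any clear loss in this cell assay, but it cannot show a clear gain, and the one-sided comparison is set by the assay's limit: the limit of > 10000 nM in this assay, at which 1 of the 4 values shown sits.

The compounds shown leave open whether a shorter or longer chain, or a chain ending in a primary amine or a dimethylamino group, would move the value clearly beyond the scatter. They also leave open whether the nitrogen in the chain matters at all, which a plain butyl chain on the same position could test.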